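The source may report more compounds than this note shows. Statements on the series, on what has been measured and on what is new or still open speak of the compounds shown alone.

Measured so far:
Compound 1 `O=C(Nc1cccc(-n2cc(-c3ccncc3)c(-c3ccc(Cl)c(O)c3)n2)c1)Nc1ccc(Cl)c(Cl)c1` — in a functional assay on OVCAR-4 cells (Homo sapiens) for inhibition, read by sulforhodamine B assay, with a stated time of 48 h (a higher number here means that more compound is tolerated, a lower number that less compound is tolerated), compound 1 gives > 32500 nM, a limit of the assay rather than a number.
Compound 2 `COc1cc(-c2nn(-c3cccc(NC(=O)Nc4ccc(Cl)c(C(F)(F)F)c4)c3)cc2-c2ccncc2)ccc1Cl` — compound 2 gives > 32500 nM, likewise a limit and not a number.

Among the measured compounds shown here, compound 2 therefore stands only at a limit; the one further value shown is also a limit, and both sit at the limit of > 32500 nM in this assay, at which 2 of the 2 values shown sit. For the measured compounds named here, no step between measured compounds that differ in one place is available, so no measured direction is known for any single change.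

Compound 3 `O=C(Nc1cccc(-n2cc(-c3ccncc3)c(-c3ccc(Cl)c(O)c3)n2)c1)Nc1ccc(Cl)c(C(F)(F)F)c1` differs from compound 2 by hydrogen in place of methyl on an oxygen on an aromatic ring. With nothing measured for this change, no step beyond the scatter is expected in either direction, and a further limit is the likeliest outcome. Compound 3 is expected to give 40000 nM, in a range from 12000 nM to 130000 nM. The step this implies is estimated as a step that the limit leaves unreadable from compound 2 to compound 3.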

Compound 3, concentration lethal to 50% of the cells: > 32500 nM
Compound 3 was reported as a limit; the forecaster's own chance of this, stated with the estimate: 80%; the middle value is on the limit's open side.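

Compound 1, compound 2 and compound 3 are all reported as limits, so neither methoxy to hydroxy nor trifluoromethyl in place of chloro gives a readable step: the limit of > 32500 nM in this assay, at which 3 of the 3 values shown sit.

The compounds shown leave open whether either change has any effect, and how large it is.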